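A few compounds are considered here, and "the series" means these few. Any claim that something is new, unique, unknown or untested is made for them only; others in the source may bear on it.

Working notes on the series, measured in an ADME assay on HEK293 cells (Homo sapiens) for cytotoxicity, read by MTT assay, with a stated time of 24 h; on this read-out lower numbers stand for stronger inhibition and higher numbers for weaker inhibition. Of the compounds shown here, two have numbers so far. Compound 1 `CN1CCN(c2nc3cc([N+](=O)[O-])ccc3nc2NCc2ccc(C(F)(F)F)cc2)CC1` gives 6.99 ug/mL and compound 2 `CN(C)CCCNc1nc2cc([N+](=O)[O-])ccc2nc1NCc1ccccc1` gives 2.74 ug/mL. Compound 2 therefore holds the lower of the two numbers, and the gap between them lies beyond the scatter. These two compounds differ in more than one place, so their gap cannot be assigned to any single change and offers no measured guide to the size of a one-place step.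

Compound 3 `COc1ccc(CNc2nc3ccc([N+](=O)[O-])cc3nc2NCCCN(C)C)cc1` is compound 2 with methoxy in place of hydrogen on an aromatic carbon of the benzyl group, para to a large group, turning benzylamino into (4-methoxybenzyl)amino: methoxy in place of hydrogen on an aromatic carbon.

Among the compounds with values here, with no one-place step measured in this assay, compound 2 at 2.74 ug/mL is the only direct anchor, and no step beyond the scatter is expected in either direction. The estimated 1.1-fold higher number from compound 2 to compound 3 (0.04 log units; within the scatter) is expected to be small, with a slight lean towards a higher number. For compound 3 the expected value is 3 ug/mL, within an estimated range of 1.1 ug/mL to 8 ug/mL.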

Compound 3, half-maximal inhibitory concentration: 38.6 ug/mL
The estimate for compound 3 lay 13-fold (1.11 log units) below the measured number; the measured number lies above the stated range.
By their numbers in this assay, from the lowest: compound 2; then compound 1; then compound 3.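

In this assay, within the data shown here, the first one-place step is large: adding methoxy in place of hydrogen on an aromatic carbon of the benzyl group, para to a large group, gives a 14-fold higher number from compound 2 to compound 3 (1.15 log units; beyond the scatter) and so moves the read-out towards weaker inhibition. This place on the benzyl group is thus not silent, as a change of only 2 heavy atoms gives a step beyond the scatter, which the gap between compound 1 and compound 2 could not show with those two differing in more than one place. Nothing measured on these compounds accounts for the size of this step.

As far as these compounds go, whether the step belongs to methoxy itself or to any group at this place remains open, and fluorine, hydroxyl or the longer ethoxy on the same carbon would begin to separate these readings. Also open, from the compounds shown here alone, is whether methoxy in place of hydrogen gives a step of similar size in the setting of compound 1, where the amine part differs from that of compound 2.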